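Moving the Fluorine Around the Outer Phenyl Ring

The compounds below may be only part of what the source reports. "The series", "measured", "known", "first", "only" and "open" are said of these compounds alone.

Going by the values given here, compound 2 `CC#CC(CC(=O)O)c1ccc(OCc2ccn3cc(-c4ccc(F)cc4)nc3c2)cc1` is one of two compounds measured in an assay on isolated protein for agonist activity at Free fatty acid receptor 1 (Homo sapiens); a higher number here means that more compound is needed for the effect, a lower number that less compound is needed; compound 2 gives 783 nM. Its companion compound 1 `CC#CC(CC(=O)O)c1ccc(OCc2ccn3cc(-c4ccc(C)cc4C)nc3c2)cc1` gives 503 nM in this assay, and the step of a 1.6-fold higher number from compound 1 to compound 2 (0.19 log units; within the scatter) exchanged one outer ring group for another. Compound 3 `CC#CC(CC(=O)O)c1ccc(OCc2ccn3cc(-c4ccccc4F)nc3c2)cc1` differs from compound 2 by 2-fluorophenyl in place of 4-fluorophenyl on an aromatic carbon. Among the compounds with values here, the only measured step that bears on this, the exchange between compound 1 and compound 2, stayed within the scatter, so no shift beyond the scatter is expected in this assay. Compound 3 is therefore estimated at 700 nM, within 250 nM to 2000 nM, an expected step of a 1.1-fold lower number from compound 2 to compound 3 (0.05 log units; within the scatter).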

Compound 3, half-maximal effective concentration: 705 nM
Beside the measured number, compound 3's estimate is 1.0-fold (0.00 log units) below it, and the stated range covers the measured number.
By their numbers in this assay, from the lowest: compounds 1, 3 and 2 (each within the scatter of the next).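

Moving the fluorine, from 4-fluorophenyl to 2-fluorophenyl, gives a 1.1-fold lower number from compound 2 to compound 3 (0.05 log units; within the scatter) in this assay and so shows no readable effect of where the fluorine sits on this outer ring. Putting 2-fluorophenyl in place of 2,4-dimethylphenyl on the same aromatic carbon gives a 1.4-fold higher number from compound 1 to compound 3 (0.15 log units; within the scatter) and is also not a readable change. Nothing available explains why these exchanges leave the number within the scatter. Still open, as far as these compounds go, is whether an outer ring carrying an amine or a carboxylic acid would move the number beyond the scatter.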